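Hydrazone series at the adenosine receptor: estimating compound 4

This account rests on a few compounds, and the source may have more. Where it says the series, first, only, none or still open, it means among the compounds named here.

Measured compounds:
compound 1 `Nc1nc(N/N=C/c2cccnc2Cl)nc2c1ncn2[C@@H]1O[C@H](CO)[C@@H](O)[C@H]1O` — 4.6 nM
compound 2 `Nc1nc(N/N=C/c2ccc(Br)cn2)nc2c1ncn2[C@@H]1O[C@H](CO)[C@@H](O)[C@H]1O` — 4.7 nM
compound 3 `Nc1nc(N/N=C/c2ccc(-c3ccccc3)cc2)nc2c1ncn2[C@@H]1O[C@H](CO)[C@@H](O)[C@H]1O` — 7860 nM

In an assay on CHO-K1 cells for displacement of a labelled ligand from adenosine receptor A1 (Homo sapiens), read by scintillation counting, with a stated time of 60 min (a higher number here means a weaker inhibitor, a lower number a stronger inhibitor), compound 1 gives 4.6 nM and compound 2 gives 4.7 nM; the step of a 1.0-fold higher number from compound 1 to compound 2 (0.01 log units; within the scatter) lies within the scatter. Compound 3 gives 7860 nM, the highest of the three numbers, beyond the scatter from both compound 1 and compound 2. Compound 4 `Nc1nc(N/N=C/c2ccc(C(F)(F)F)cc2)nc2c1ncn2[C@@H]1O[C@H](CO)[C@@H](O)[C@H]1O` differs from compound 3 by trifluoromethyl in place of phenyl on an aromatic carbon. For the measured compounds named here, no measured step covers this change; the one measured step concerns the two pyridinyl compounds and does not involve the phenyl-bearing compound 3. The expectation rests only on compound 3 being much weaker than compound 1 and compound 2 with a smaller group entering. Compound 4 is expected to give 600 nM (range 60 nM to 6000 nM), an expected step of a 13-fold lower number from compound 3 to compound 4 (1.12 log units; beyond the scatter).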

Compound 4, inhibition constant: 37 nM
Compound 4: middle estimate off by 16-fold (1.21 log units), on the high side; the whole stated range lies above it.
By their numbers in this assay, from the lowest: compounds 1 and 2 (each within the scatter of the next); then compound 4; then compound 3.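

In this assay trifluoromethyl in place of phenyl on this aromatic carbon gives a 210-fold lower number from compound 3 to compound 4 (2.33 log units; beyond the scatter) in a single change, so the high number of compound 3 goes with the phenyl group at this place, not with the carbon-only ring that carries it. Compound 1 and compound 2 still lie lower, with a 7.9-fold higher number from compound 2 to compound 4 (0.90 log units; beyond the scatter) and an 8.0-fold higher number from compound 1 to compound 4 (0.91 log units; beyond the scatter) across changes of the whole aryl group, so ring and substituent cannot be separated. Nothing available explains these steps.

From the compounds shown here alone, whether a methoxy group or an amine on this carbon would lie nearer compound 4 or compound 3 remains open. So does whether a pyridine ring carrying trifluoromethyl would reach the level of compound 1 and compound 2.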